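Fluoromethyl in Place of Hydroxymethyl on a Shared Core

The source may report more compounds than this note shows. Statements on the series, on what has been measured and on what is new or still open speak of the compounds shown alone.

In a functional assay on HL-60 cells (Homo sapiens) for cytotoxicity, read by WST assay, with a stated time of 48 h (on this read-out lower numbers stand for stronger inhibition and higher numbers for weaker inhibition), compound 3 (`COc1cc(C(c2ccc(O)c(OC)c2)[C@@H](C)[C@@H](C)CO)ccc1O`) gives only a limit, > 100000 nM, not a number. Among the compounds shown it stands at the high end: compound 1 (`COc1cc(C(c2ccc(O)c(OC)c2)[C@H](C)[C@@H](C)CF)ccc1O`) gives 45000 nM, compound 2 (`COc1cc(C(c2ccc(O)c(OC)c2)[C@H](CC(C)C)C(C)C)ccc1O`) gives 9600 nM, and the number rose an at least 2.2-fold higher number from compound 1 to compound 3 (0.34 log units; beyond the scatter) and an at least 10-fold higher number from compound 2 to compound 3 (1.01 log units; beyond the scatter). Compound 4 (`COc1cc(C(c2ccc(O)c(OC)c2)[C@H](CF)C(C)C)ccc1O`) differs from compound 3 in one place: 1-(fluoromethyl)-2-methylpropyl in place of 2-(hydroxymethyl)-1-methylpropyl on a saturated chain carbon bound to two aromatic carbons. The step that bears on this is an at least 2.2-fold higher number from compound 1 to compound 3 (0.34 log units; beyond the scatter), where 2-(hydroxymethyl)-1-methylpropyl in place of 2-(fluoromethyl)-1-methylpropyl raised the number; compound 4 carries a fluoromethyl-bearing chain again, so the reverse is expected, a modest lowering, an at least 2.2-fold lower number from compound 3 to compound 4 (0.34 log units; beyond the scatter). Compound 4 is therefore estimated at 45000 nM, between 15000 nM and 130000 nM.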

Compound 4, half-maximal inhibitory concentration: 19000 nM
The estimate for compound 4 lay 2.4-fold (0.37 log units) above the measured number; the range from low to high includes it.
By their numbers in this assay, from the lowest: compounds 2 and 4 (each within the scatter of the next); then compound 1. At a limit, above all of these: compound 3.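

Going by these compounds, replacing the hydroxyl-bearing chain with a fluorine-bearing one at this position lowers the number again (an at least 5.2-fold lower number from compound 3 to compound 4 (0.72 log units; beyond the scatter)), and the true size of that step stays unknown, since compound 3 gives only a limit: the limit of > 100000 nM in this assay, at which 1 of the 4 values shown sits. The arrangement of the chain also matters, as moving the fluoromethyl group from the 2-(fluoromethyl)-1-methylpropyl form to the 1-(fluoromethyl)-2-methylpropyl form gives a real change (a 2.4-fold lower number from compound 1 to compound 4 (0.37 log units; beyond the scatter)). The fluorine-bearing chain and the all-carbon 1-isopropyl-3-methylbutyl chain cannot be told apart (a 2.0-fold higher number from compound 2 to compound 4 (0.30 log units; within the scatter)). On these data alone, how an amine, a carboxylic acid or a longer fluorine-bearing chain would behave here remains open.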